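A Methyl Group on an Aromatic Nitrogen and Lipophilicity

The source may hold more compounds than are shown below. What is called first, only, known or untested is meant among the compounds shown, and "the series" means these compounds.

Measured compounds:
compound 1, `Cn1cc(C(=O)N2CCC(C(N)=O)CC2)c2ccccc21`, with 1.1 in a physicochemical assay for lipophilicity, read by HPLC, measured as octanol-water partition, at pH 2; on this read-out lower numbers stand for lower lipophilicity and higher numbers for higher lipophilicity
compound 2, `O=C(Cn1ccccc1=O)Nc1cc2ccccc2[nH]1`, with 1 in this assay
compound 3, `NC(=O)C1CCN(C(=O)c2c[nH]c3ccccc23)CC1`, with 0.3 in this assay

Compound 3 and compound 1 differ in one place only: methyl in place of hydrogen on an aromatic nitrogen. This single change made the step of a number 0.80 log units higher from compound 3 to compound 1 (beyond the scatter). Compound 2 and compound 1 lie within the usual scatter of each other, so nothing separates them in this assay; compound 2 does stand above compound 3 by more than that scatter. How the core of compound 2 differs from the core of compound 3 is not broken down here.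

Compound 4, `Cn1c(NC(=O)Cn2ccccc2=O)cc2ccccc21`, has not yet been measured. It differs from compound 2 by methyl in place of hydrogen on an aromatic nitrogen. For the measured compounds named here, this is the same kind of change as the one from compound 3 to compound 1, but not the same: in compound 1 the methyl sits two ring bonds from the ring atom that bears a large group, in compound 4 it sits next to the ring atom that bears a large group.

Going by the values given here, from compound 2 to compound 4 a step of a number 0.80 log units higher from compound 2 to compound 4 (beyond the scatter) is expected, set beside a number 0.80 log units higher from compound 3 to compound 1 (beyond the scatter), because the measured step of a number 0.80 log units higher from compound 3 to compound 1 (beyond the scatter) is the only guide available for this kind of change. Compound 4 is therefore estimated at 1.8, expected to fall between 1.3 and 2.3.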

Compound 4, distribution coefficient: 1.5
For compound 4 the middle estimate is 0.30 log units above the measured one, and the stated range covers the measured number.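

In this assay, the new result is a number 0.50 log units higher from compound 2 to compound 4 (beyond the scatter), while the earlier step on a different core is a number 0.80 log units higher from compound 3 to compound 1 (beyond the scatter). This shows that, in these two pairs, placing a methyl in place of hydrogen on an aromatic nitrogen moved the number in the same direction on both cores, but two pairs are too few to establish a rule or to fix a size that could be relied on for another core, and in compound 4 the methyl also sits next to the ring atom that bears a large group, so a change of core cannot be told apart from a change of place. No measurement shown here explains why either step has the size it does.

The compounds shown leave open whether a longer chain, such as ethyl, on the same aromatic nitrogen would move the number in this assay in the same direction as methyl does. They also leave open how the methyl step would read on a core that carries an amine or a carboxylic acid, since neither group appears in these compounds.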